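Swapping Dichlorophenyl for Methylphenyl on a Hydrazone Carbon

The source may report more compounds than this note shows. Statements on the series, on what has been measured and on what is new or still open speak of the compounds shown alone.

Measured compounds:
compound 1, `N/C(CC(O)c1ccc2ccccc2c1)=N\N=C\c1ccc(Cl)c(Cl)c1`: 100000 nM
compound 2, `CCOc1cc(/C=N/N=C(\N)CC(O)c2cccc3ccccc23)ccc1O`: 4200 nM

Both were run in an ADME assay on L6 cells (Rattus norvegicus) for cytotoxicity, read by resazurin assay, with a stated time of 72 h; on this read-out lower numbers stand for stronger inhibition and higher numbers for weaker inhibition. Compound 1 gives 100000 nM, and compound 2 gives 4200 nM. Compound 1 thus stands at the highest of the two numbers, and the gap to compound 2 lies beyond the usual scatter, so compound 1 is the less cytotoxic of the pair. Among the compounds with values here, compound 2 differs from compound 1 in more than one place, so no single structural step between them can be read from these two values.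

Compound 3, `Cc1ccc(/C=N/N=C(\N)CC(O)c2ccc3ccccc3c2)cc1`, has not yet been measured in this assay. It differs from compound 1 in one place:

4-methylphenyl in place of 3,4-dichlorophenyl on a carbon with a double bond to nitrogen

Within the data shown here, no measured pair shows what this change does on its own. With nothing pointing either way, the step of no change at the digits printed from compound 1 to compound 3 (within the scatter) is expected to fall within the scatter, with no clear direction. Compound 3 is therefore estimated at 100000 nM, in a range from 30000 nM to 300000 nM.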

Compound 3, half-maximal inhibitory concentration: 103000 nM
The estimate for compound 3 lay 1.0-fold (0.01 log units) below the measured number; measured number inside the range.
By their numbers in this assay, from the lowest: compound 2; then compounds 1 and 3 (each within the scatter of the next).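

In this assay, within the data shown here, putting 4-methylphenyl in place of 3,4-dichlorophenyl on a carbon with a double bond to nitrogen gives a 1.0-fold higher number from compound 1 to compound 3 (0.01 log units; within the scatter), which is the first comparison here that isolates a single structural exchange. At this position, then, a ring carrying the two chlorine atoms and a ring carrying one methyl group cannot be told apart in this cell test, even though the two groups share only the six-membered aromatic ring of carbon. Nothing available explains why the two groups read alike.

A ring bearing an amine or a carboxylic acid at this same place remains an open case, since the two groups compared here hold no hydrogen-bond donors or acceptors and no net charge. Also open, on these data alone, is whether the same exchange would read alike on the core of compound 2, which differs from compound 1 in more than one place and so says nothing about this step.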